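The source may report more compounds than this note shows. Statements on the series, on what has been measured and on what is new or still open speak of the compounds shown alone.

Measured in a functional assay on DU-145 cells (Homo sapiens) for inhibition, read by trypan blue exclusion, with a stated time of 96 h; on this read-out higher numbers stand for weaker inhibition of growth and lower numbers for stronger inhibition of growth:
- compound 1 `O=C(/C(=C\c1ccc(O)cc1)SCc1ccc(Cl)cc1)c1ccc(Br)cc1`: 10000 nM
- compound 2 `COc1ccc(/C=C(/SCc2ccc(Cl)cc2)C(=O)c2ccc(Br)cc2)cc1`: 10000 nM

Level with compound 1, compound 2 stands at 10000 nM. Among the measured compounds shown here, no other measured compound lies near it. For the measured compounds named here, compound 3 `O=C(/C(=C\c1cccc(Cl)c1Cl)SCc1ccc(Cl)cc1)c1ccc(Br)cc1` has no measurement yet. It differs from compound 2 as follows: 2,3-dichlorophenyl in place of 4-methoxyphenyl on a double-bonded chain carbon bound to a double-bonded chain carbon.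

Going by the values given here, one measured step bears on this change: no change at the digits printed from compound 1 to compound 2 (within the scatter). It falls on the group that leaves here, so that group has been altered once, on its oxygen, with no visible result. The evidence is thin, however. Among the compounds with values here, that step only adds a methyl, whereas the new change replaces the whole group with 2,3-dichlorophenyl, and no measured compound carries this group. The data therefore fix no direction. The working expectation is a step within the scatter, with a slight and loosely held lean towards stronger inhibition of growth.

The step expected in this assay is a 1.4-fold lower number from compound 2 to compound 3 (0.15 log units; within the scatter).

For compound 3 the estimate is 7000 nM, with an expected range of 2000 nM to 20000 nM.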

Compound 3, concentration for 50% growth inhibition: 10000 nM
Compound 3: middle estimate off by 1.4-fold (0.15 log units), on the low side; the range from low to high includes it.
By their numbers in this assay, from the lowest: compounds 1, 2 and 3 (each within the scatter of the next).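

In this assay, the position on a double-bonded chain carbon bound to a double-bonded chain carbon has now taken a replacement of the whole group, not only a methyl on its oxygen: 2,3-dichlorophenyl in place of 4-methoxyphenyl gives no change at the digits printed from compound 2 to compound 3 (within the scatter), and 2,3-dichlorophenyl in place of 4-hydroxyphenyl gives no change at the digits printed from compound 1 to compound 3 (within the scatter). The three aromatic groups therefore cannot be told apart on this read-out, even though the entering group swaps the oxygen of the earlier groups for two chlorines and has no hydrogen-bond acceptor where 4-methoxyphenyl has one. No supporting evidence bears on why the reading stays flat across these groups.

As far as these compounds go, it remains open whether any group at this position can shift the reading, for example a phenyl ring carrying an amine or a carboxylic acid, or a longer chain in place of the ring. Also open, from the compounds shown here alone, is how far the reading depends on the rest of the shared core, which is identical in compound 1, compound 2 and compound 3.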